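The source may hold more compounds than are shown below. What is called first, only, known or untested is meant among the compounds shown, and "the series" means these compounds.

Measured so far:

compound 1, `CCOc1cc2ncnc(Nc3ccc(F)c(Cl)c3)c2cc1NC(=O)COC(C)=O`, gives 3400 nM.
compound 2, `CCOc1cc2ncnc(Nc3ccc(F)c(Cl)c3)c2cc1NC(=O)COC(=O)c1ccccc1`, gives 8300 nM.

Both measurements come from a functional assay on NCI-H1975 cells (Homo sapiens) for inhibition, read by MTT assay, with a stated time of 72 h; a lower number here means a stronger inhibitor, a higher number a weaker inhibitor. Among the measured compounds shown here, of the two numbers, compound 2 stands at the higher end: its single neighbour is compound 1, and the step of a 2.4-fold higher number from compound 1 to compound 2 (0.39 log units; beyond the scatter) is the only comparison available. That step swaps a methyl for a phenyl on the carbonyl carbon of the ester at the end of the side chain, and it made the compound a modestly weaker inhibitor.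

Compound 3, `CCOc1cc2ncnc(Nc3ccc(F)c(Cl)c3)c2cc1NC(=O)COC(=O)c1c(C)cccc1C`, is not yet measured. It differs from compound 2 in one place: 2,6-dimethylphenyl in place of phenyl on a carbonyl carbon. For the measured compounds named here, the same part of the molecule is being changed again, and the one step that touched it, the change from compound 1 to compound 2, ran towards a higher number. Going by the values given here, there is no measured step that shows what adding methyl groups to this phenyl ring does, so the expectation rests only on that single earlier step and on the modest size of it.

Compound 3 is therefore expected to give roughly 11000 nM in this assay, within a range from 4000 nM to 30000 nM. This estimate means a 1.3-fold higher number from compound 2 to compound 3 (0.12 log units; within the scatter), a step expected to be small and near the edge of the usual scatter.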

Compound 3, half-maximal inhibitory concentration: 6100 nM
Compound 3: middle estimate off by 1.8-fold (0.26 log units), on the high side, and the stated range covers the measured number.
By their numbers in this assay, from the lowest: compounds 1, 3 and 2 (each within the scatter of the next, the first and the last beyond it).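

In this assay, placing two methyl groups on the phenyl ring of the ester gives a 1.4-fold lower number from compound 2 to compound 3 (0.13 log units; within the scatter), so 2,6-dimethylphenyl and phenyl cannot be told apart at this carbonyl carbon. Compared with the small methyl group at the same place, 2,6-dimethylphenyl gives a 1.8-fold higher number from compound 1 to compound 3 (0.25 log units; within the scatter), which also cannot be told apart, even though the methyl and phenyl esters themselves differ by a 2.4-fold higher number from compound 1 to compound 2 (0.39 log units; beyond the scatter); compound 3 therefore lies within the scatter of both, and this position accepts all three groups with at most a modest difference in the number. Nothing available here bears on why these three esters read so closely.

The compounds shown leave open whether a phenyl ring with a single methyl group or a chlorine would behave like these two aromatic esters. They also leave open what happens when the ester at the end of the side chain gives way to a free hydroxyl, an amine, a carboxylic acid or a longer chain.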